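The compounds below may be only part of what the source reports. "The series", "measured", "known", "first", "only" and "open" are said of these compounds alone.

Measured so far:
Compound 1, `Oc1cccc(-c2cc(-c3cccc(F)c3)cc(-c3ccccc3O)n2)c1`: in a functional assay on T47D cells (Homo sapiens) for inhibition (on this read-out higher numbers stand for weaker inhibition and lower numbers for stronger inhibition), compound 1 gives > 50000 nM, a limit of the assay rather than a number.
Compound 2, `Oc1cccc(-c2cc(-c3ccc(C(F)(F)F)cc3)cc(-c3ccccc3O)n2)c1`: in this assay compound 2 gives > 50000 nM, again a limit of the assay rather than a number.

Compound 2 therefore stands at the edge of what the assay can report: for it only a limit is shown, and the same holds for the one other value shown, so that the limit of > 50000 nM in this assay, at which 2 of the 2 values shown sit, describes every measured value here. Among the measured compounds shown here, the single measured step, a step that the two limits leave unreadable from compound 1 to compound 2, has two limits as its ends and cannot be read. Compound 3, `Oc1cccc(-c2cc(-c3ccc(C(F)(F)F)cc3)cc(-c3cccc(O)c3)n2)c1`, has not yet been measured. It differs from compound 2 in one place: 3-hydroxyphenyl in place of 2-hydroxyphenyl on an aromatic carbon. For the measured compounds named here, no measured step bears on this change, and the one step that exists is itself unreadable, so no direction or size can be taken from the data. The expectation is simply that compound 3 stays where its neighbours sit, with an expected step that the limit leaves unreadable from compound 2 to compound 3 meaning no change that the assay could resolve. Compound 3 is therefore estimated at 60000 nM, within 10000 nM to 300000 nM, most likely again reported only as a limit.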

Compound 3, half-maximal inhibitory concentration: 2330 nM
Beside the measured number, compound 3's estimate is 26-fold (1.41 log units) above it; measured number outside the range, below it.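

The carbon next to the ring nitrogen is a sensitive place in this assay: 3-hydroxyphenyl in place of 2-hydroxyphenyl gives an at least 21-fold lower number from compound 2 to compound 3 (1.33 log units; beyond the scatter), even though the two compounds have the same atoms, joined differently. Compound 2 gives > 50000 nM, which is a limit of the assay, so the printed size of this step is only a minimum. Compound 3 is the only compound here with a real number, and this step shows that the read-out can respond to a change in this series, which the pair of compound 1 and compound 2, whose step cannot be read, could not show; the other values stay at the limit: the limit of > 50000 nM in this assay, at which 2 of the 3 values shown sit.

As far as these compounds go, it remains open whether the gain comes from the 3-hydroxyphenyl group alone or also depends on the 4-(trifluoromethyl)phenyl group that compound 3 carries, as 3-hydroxyphenyl appears here only alongside that group. Also open is what other groups would do at this place, such as 4-hydroxyphenyl, plain phenyl, or a phenyl ring carrying an amine or a carboxylic acid instead of the hydroxyl, and the compounds shown do not tell why this change acts as it does.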